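Swapping a Furan for a Dimethoxyphenyl on the Shared Core

The source may report more compounds than this note shows. Statements on the series, on what has been measured and on what is new or still open speak of the compounds shown alone.

Of the compounds shown here, two have been measured so far in a functional assay for inhibition, tested at 80 ug/mL; a higher number here means a stronger effect of the compound at the concentration tested, a lower number a weaker effect. Compound 1 `Cc1cc(O)c(C(C)C)cc1-c1cc(-c2cccs2)c(C#N)c(=O)[nH]1` gives 63%, and compound 2 `Cc1cc(O)c(C(C)C)cc1-c1cc(-c2ccco2)c(C#N)c(=O)[nH]1` gives 64%. Compound 2 stands highest of the two numbers, but its nearest neighbour, compound 1, sits only a number 1 percentage points higher from compound 1 to compound 2 (within the scatter), so the two are not separated beyond the scatter of the measurement.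

The next compound, compound 3 `COc1ccc(-c2cc(-c3cc(C(C)C)c(O)cc3C)[nH]c(=O)c2C#N)cc1OC`, has not yet been measured. It differs from compound 2 in one place: 3,4-dimethoxyphenyl in place of furan-2-yl on an aromatic carbon. Within the data shown here, the only measured step that touches this place is the one from compound 1 to compound 2, which exchanged one five-membered heteroaryl for another and gave a number 1 percentage points higher from compound 1 to compound 2 (within the scatter). That step is small and concerns a different kind of exchange, so it gives no firm guide for the larger group entering here. Among the measured compounds shown here, with no measured step pointing either way, the expected change is a number 4 percentage points lower from compound 2 to compound 3 (within the scatter), no larger than the scatter. Compound 3 is therefore estimated at 60%, with a range from 35% to 80%.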

Compound 3, a percentage reported as inhibition, at one concentration (the size of the read-out at that concentration, not a potency): 58%
Compound 3: the middle estimate sits 2 percentage points above what was measured, within the range that was stated.
By their numbers in this assay, from the lowest: compounds 3, 1 and 2 (each within the scatter of the next).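

At the aromatic carbon opposite the ring nitrogen and ortho to a cyano group, exchanging the earlier rings for 3,4-dimethoxyphenyl gives a number 6 percentage points lower from compound 2 to compound 3 (within the scatter) when furan-2-yl leaves and a number 5 percentage points lower from compound 1 to compound 3 (within the scatter) when thiophen-2-yl leaves, both read in this assay and neither separable from no change. The earlier pair had exchanged only one five-membered aromatic ring for another, whereas here a six-membered aromatic ring of carbon only, with 10 heavy atoms in place of 5 and two methoxy groups, enters without moving the read-out beyond the scatter, so among these three compounds this position accepts a much larger group. No independent measurement is available to explain this outcome.

Left open is whether the two methoxy groups contribute anything, since a plain phenyl ring or a single methoxy group is not among the compounds shown, and whether a different kind of group here, such as an amine or a carboxylic acid, would shift the number beyond the scatter. As the read-out comes from a single concentration, the compounds shown also leave open whether their effects would differ at other concentrations.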